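Swapping the Amide Aryl Group of Compound 2

The source may hold more compounds than are shown below. What is called first, only, known or untested is meant among the compounds shown, and "the series" means these compounds.

Measured so far:
compound 1 `O=C(Nc1cccc(-c2oc3cc(-c4ccc(F)cc4)ccc3c(=O)c2O)c1)c1ccc(Cl)cc1` — 11000 nM
compound 2 `O=C(Nc1cccc(-c2oc3cc(-c4ccc(F)cc4)ccc3c(=O)c2O)c1)c1ccc(C(F)(F)F)cc1` — 42700 nM

In a functional assay on HepG2 cells (Homo sapiens) for antiproliferative activity, read by CCK-8 assay, with a stated time of 72 h (on this read-out higher numbers stand for weaker inhibition and lower numbers for stronger inhibition), compound 1 gives 11000 nM, and compound 2 gives 42700 nM. Within the data shown here, compound 2 thus has the higher of the two numbers; the only measured step, a 3.9-fold higher number from compound 1 to compound 2 (0.59 log units; beyond the scatter), separates it from compound 1.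

Compound 3 `O=C(Nc1cccc(-c2oc3cc(-c4ccc(F)cc4)ccc3c(=O)c2O)c1)c1ccc(Br)cc1F` is unmeasured. Its change from compound 2: 4-bromo-2-fluorophenyl in place of 4-(trifluoromethyl)phenyl on a carbonyl carbon. Among the measured compounds shown here, the one step that bears on this is a 3.9-fold higher number from compound 1 to compound 2 (0.59 log units; beyond the scatter), where a halogen gave way to trifluoromethyl; here trifluoromethyl gives way to a halogen again, though with an added fluorine whose effect is untested. A lower number is therefore expected. Compound 3 is estimated at 15000 nM, within 5000 nM to 45000 nM, an expected step of a 2.8-fold lower number from compound 2 to compound 3 (0.45 log units; beyond the scatter).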

Compound 3, half-maximal inhibitory concentration: > 100000 nM
Compound 3 ended at the assay's limit (the forecaster's own chance of this, stated with the estimate: 10%); middle value at least 6.6-fold (0.82 log units) away from the limit.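

The value of compound 3 in this assay is a limit of the assay, not a number: the limit of > 100000 nM in this assay, at which 1 of the 3 values shown sits.

Measured against the two earlier compounds, there is an at least 2.3-fold higher number from compound 2 to compound 3 (0.36 log units; beyond the scatter), and there is an at least 9.0-fold higher number from compound 1 to compound 3 (0.95 log units; beyond the scatter). Putting a halogen back in place of trifluoromethyl therefore does not by itself give a lower number at this carbonyl carbon: compound 1 follows that idea, while compound 3 goes against it.

Compound 3 differs from compound 1 in both its bromine and its added fluorine, so which of the two accounts for the step stays open. As far as these compounds go, how an amine or a carboxylic acid on this ring would read also stays open.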